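The source may report more compounds than this note shows. Statements on the series, on what has been measured and on what is new or still open speak of the compounds shown alone.

Working notes on the series. In a functional assay on the whole organism (strain Sprague-Dawley CD) for inhibition, with Rattus norvegicus as the target, read by paw edema, at a dose of 100 mg/kg by the oral route (on this read-out higher numbers stand for a stronger effect at the one dose given and lower numbers for a weaker effect), compound 2 `CC(C)OC(=O)C(=O)Nc1cccccc1=O` gives 72%, the higher of the two numbers in hand; compound 1 `CCOC(=O)C(=O)Nc1ccccc(Oc2ccccc2)c1=O` gives 9%, a gap beyond the scatter. Compound 3 `O=C(O)COC(=O)C(=O)Nc1cccccc1=O` is not yet measured. Against compound 2 the change is carboxymethyl in place of isopropyl on an oxygen next to a carbonyl group. Going by the values given here, no measured pair carries a comparable change, so the expected step from compound 2 to compound 3, a number 22 percentage points lower from compound 2 to compound 3 (beyond the scatter), is a guess: a moderate drop is expected, though a step within the scatter cannot be ruled out. Compound 3 is expected to give about 50%, in the range 20% to 80%.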

Compound 3, a percentage reported as inhibition, in the whole organism at one dose (the size of the read-out at that dose, not a potency): 50%
Estimate against measurement, compound 3: no gap at the digits printed; measured number inside the range.
By their numbers in this assay, from the lowest: compound 1; then compound 3; then compound 2.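

In this assay, carboxymethyl in place of isopropyl on an oxygen next to a carbonyl group gives a number 22 percentage points lower from compound 2 to compound 3 (beyond the scatter), the first step read at this place. The effect is reduced but not lost: compound 3 still gives 50% while carrying a hydrogen-bond donor and acceptor that isopropyl lacks. Nothing at hand gives a reason for this step. Open at this place is how a longer chain or an amine would compare with isopropyl and carboxymethyl. Also open, from the compounds shown here alone, is whether a carboxylic acid set further out along a longer chain would give a similar step.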